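Hydroxy to methoxy on the thiophene-bearing series

The compounds below may be only part of what the source reports. "The series", "measured", "known", "first", "only" and "open" are said of these compounds alone.

Measured in a functional assay on the whole organism for inhibition, with Rattus norvegicus as the target; a lower number here means a stronger inhibitor, a higher number a weaker inhibitor:
- compound 1 `O=C1ON=C(c2cccs2)/C1=C/c1ccc(O)cc1`: 4200 nM
- compound 2 `Cc1cc(/C=C2\C(=O)ON=C2c2cccs2)cc(C)c1O`: 2600 nM

Going by the values given here, only two numbers exist so far, and compound 1 at 4200 nM lies within the scatter of compound 2 at 2600 nM, so the two carry no order.

Compound 3 `COc1ccc(/C=C2\C(=O)ON=C2c2cccs2)cc1` has methyl in place of hydrogen on an oxygen on an aromatic ring, hydroxy to methoxy: methyl in place of hydrogen on an oxygen on an aromatic ring.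

Among the compounds with values here, no measured pair isolates a single change, so the expectation in this assay is weakly founded: no step beyond the scatter, and no firm direction. The estimated change is a 1.1-fold higher number from compound 1 to compound 3 (0.03 log units; within the scatter). Compound 3 is expected at 4500 nM, with an estimated range of 1600 nM to 12000 nM.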

Compound 3, half-maximal inhibitory concentration: 2500 nM
The estimate for compound 3 lay 1.8-fold (0.26 log units) above the measured number; measured number inside the range.
By their numbers in this assay, from the lowest: compounds 3, 2 and 1 (each within the scatter of the next).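

Hydroxy to methoxy gives the first pair in the series that differs in one place: a 1.7-fold lower number from compound 1 to compound 3 (0.23 log units; within the scatter) in this assay is the whole measured effect of methyl in place of hydrogen on this oxygen. The hydroxy hydrogen is therefore not needed to keep the number in this range, at least on the core of compound 1. No measurement on hand bears on why.

Still open, going by these compounds, is whether a longer chain on this oxygen, such as ethoxy, or an amine in place of the oxygen, would move the number beyond the scatter.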